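Aryl to Methylisoxazolyl Carbonyl Swap: Expected Plasma Half-Life

The compounds below may be only part of what the source reports. "The series", "measured", "known", "first", "only" and "open" are said of these compounds alone.

Measured compounds and values in an ADME assay on a cell-free system (plasma, Homo sapiens) for metabolic stability, with Plasma (Rattus norvegicus) as the target, read by HPLC, at pH 7.4; on this read-out lower numbers stand for a shorter-lived compound and higher numbers for a longer-lived compound:
- compound 1, `CC(=O)Oc1ccccc1C(=O)O[C@H]1CO[C@H]2[C@@H]1OC[C@H]2OC(=O)c1ccc(O)cc1`: 0.0198 h
- compound 2, `CC(=O)Oc1ccccc1C(=O)O[C@H]1CO[C@H]2[C@@H]1OC[C@H]2OC(=O)c1ccc(C)cc1`: 0.105 h
- compound 3, `COc1ccccc1C(=O)O[C@@H]1CO[C@H]2[C@@H]1OC[C@@H]2OC(=O)c1ccccc1OC(C)=O`: 0.0578 h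

Among the three measured compounds, compound 3 holds the second highest number in this assay. Its nearest neighbour is compound 2, and a 1.8-fold lower number from compound 2 to compound 3 (0.26 log units; within the scatter) lies within the scatter, so the two cannot be told apart. Against compound 1 the gap is clearer: a 2.9-fold higher number from compound 1 to compound 3 (0.47 log units; beyond the scatter) is beyond the scatter. The largest step seen so far is a 5.3-fold higher number from compound 1 to compound 2 (0.72 log units; beyond the scatter).

Compound 4, `CC(=O)Oc1ccccc1C(=O)O[C@H]1CO[C@H]2[C@@H]1OC[C@H]2OC(=O)c1cnoc1C`, has not yet been measured. It differs from compound 3 in one place: 5-methyl-1,2-oxazol-4-yl in place of 2-methoxyphenyl on a carbonyl carbon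

For the measured compounds named here, none of the measured steps exchanges a six-membered aromatic ring of carbon only for a five-membered aromatic ring with 2 hetero atoms on the carbonyl carbon, so no measured step bears directly on this change. What the measured steps do show is that swapping the group on this carbonyl carbon moves the half-life by modest amounts at most, and in either direction. Compound 4 is therefore estimated to sit close to compound 3, with a 1.2-fold lower number from compound 3 to compound 4 (0.06 log units; within the scatter) expected to stay within the scatter. The estimate for compound 4 is 0.05 h, with a range from 0.015 h to 0.17 h.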

Compound 4, half-life: 0.193 h
Estimate against measurement, compound 4: 3.9-fold (0.59 log units) below; the whole stated range lies below it.
By their numbers in this assay, from the lowest: compound 1; then compounds 3, 2 and 4 (each within the scatter of the next, the first and the last beyond it).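

Placing 5-methyl-1,2-oxazol-4-yl on the carbonyl carbon gives a 3.3-fold higher number from compound 3 to compound 4 (0.52 log units; beyond the scatter) in this assay, which shows that this position accepts a five-membered aromatic ring with 2 hetero atoms without any loss of half-life against 2-methoxyphenyl. Set against 4-methylphenyl, the same group gives a 1.8-fold higher number from compound 2 to compound 4 (0.26 log units; within the scatter) and so compound 2 and compound 4 cannot be told apart, while against 4-hydroxyphenyl it gives a 9.7-fold higher number from compound 1 to compound 4 (0.99 log units; beyond the scatter) and this is the widest step yet seen among the groups at this place. The change of ring type thus reaches a half-life that the carbon-only ring of compound 2 already matches, and no information is available on why the number moves with this swap.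

The compounds shown leave open what the methyl on the new ring contributes, since no 1,2-oxazol-4-yl group without it appears, nor one carrying a longer chain such as propyl in its place. They also leave open how an amine or a carboxylic acid on this ring would fare, and whether any other five-membered aromatic ring would behave like this one at the same carbonyl carbon.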